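The source may hold more compounds than are shown below. What is called first, only, known or untested is meant among the compounds shown, and "the series" means these compounds.

Measured compounds:
compound 1 `O[C@@H]1Cc2ccccc2N[C@H](c2ccccc2)C1` — > 300000 nM
compound 2 `O[C@@H]1Cc2cc(Br)ccc2N[C@H](c2ccccc2)C1` — 42100 nM
compound 3 `O[C@@H]1Cc2ccccc2N[C@H](c2ccc(F)cc2)C1` — > 300000 nM

In an ADME assay on Vero cells (Chlorocebus sabaeus) for cytotoxicity, read by MTT assay, with a stated time of 72 h (a lower number here means that less compound is tolerated, a higher number that more compound is tolerated), compound 1 gives > 300000 nM, which is a limit of the assay and not a number. Compound 2 gives 42100 nM in this assay. Compound 3 gives > 300000 nM, again a limit of the assay. Two measured steps start from compound 1. The first, bromo in place of hydrogen on an aromatic carbon of the shared core, is an at least 7.1-fold lower number from compound 1 to compound 2 (0.85 log units; beyond the scatter). The second, fluoro in place of hydrogen on the pendant phenyl ring, is a step that the two limits leave unreadable from compound 1 to compound 3, because the limit of > 300000 nM in this assay, at which 2 of the 3 values shown sit, sits on both ends of that comparison.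

Compound 4 `COc1cccc([C@@H]2C[C@H](O)Cc3ccccc3N2)c1` has not yet been measured in this assay. It differs from compound 1 by methoxy in place of hydrogen on an aromatic carbon. The change sits on the pendant phenyl ring, as in compound 3, rather than on the core ring, as in compound 2. Compound 4 is expected to remain close to where compound 1 stands, with a step of an at least 1.5-fold lower number from compound 1 to compound 4 (0.17 log units; that floor lies within the scatter), so the estimate for compound 4 is 200000 nM, between 50000 nM and 300000 nM.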

Compound 4, half-maximal cytotoxic concentration: > 300000 nM
Compound 4 was reported as a limit; the forecaster's own chance of this, stated with the estimate: 55%; middle value at least 1.5-fold (0.17 log units) from the limit.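

In this assay compound 4 gives > 300000 nM, a limit of the assay and not a number. The step between compound 1 and compound 4 cannot be read, because both ends sit at the same limit: the limit of > 300000 nM in this assay, at which 3 of the 4 values shown sit.

The compounds shown leave open whether methoxy or fluoro on the pendant phenyl ring shifts the number at all.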